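Moving the hydroxyl along the amine chain on the shared core

This account rests on a few compounds, and the source may have more. Where it says the series, first, only, none or still open, it means among the compounds named here.

Measured so far, in an assay on Cerebral cortex for displacement of a labelled ligand from adenosine receptor A1 (Bos taurus); a lower number here means a stronger inhibitor, a higher number a weaker inhibitor:
compound 1, `Clc1ccccc1Cn1nnc2c(NC3CC3)nc(-c3ccccc3)nc21`, gives 11 nM
compound 2, `Clc1ccccc1Cn1nnc2c(NC3CCC3)nc(-c3ccccc3)nc21`, gives 24 nM
compound 3, `CC(O)CNc1nc(-c2ccccc2)nc2c1nnn2Cc1ccccc1Cl`, gives 32 nM

Compound 3 holds the highest number of the three: the step of a 2.9-fold higher number from compound 1 to compound 3 (0.46 log units; beyond the scatter) lies beyond the scatter, while a 1.3-fold higher number from compound 2 to compound 3 (0.12 log units; within the scatter) does not. Compound 4, `OCCCNc1nc(-c2ccccc2)nc2c1nnn2Cc1ccccc1Cl`, differs from compound 3 by 2-hydroxyethyl in place of 1-hydroxyethyl on a saturated chain carbon bound to a nitrogen on an aromatic ring. All three measured steps vary the group on the same nitrogen, and none is large: a 2.2-fold higher number from compound 1 to compound 2 (0.34 log units; beyond the scatter), a 2.9-fold higher number from compound 1 to compound 3 (0.46 log units; beyond the scatter), a 1.3-fold higher number from compound 2 to compound 3 (0.12 log units; within the scatter). A similarly small shift, in either direction or none beyond the scatter, is therefore expected in this assay. Compound 4 is estimated at 40 nM, within 15 nM to 110 nM, meaning an expected step of a 1.3-fold higher number from compound 3 to compound 4 (0.10 log units; within the scatter).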

Compound 4, inhibition constant: 33 nM
The estimate for compound 4 lay 1.2-fold (0.08 log units) above the measured number, within the range that was stated.
By their numbers in this assay, from the lowest: compound 1; then compounds 2, 3 and 4 (each within the scatter of the next).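

In this assay, 3-hydroxypropyl in place of 2-hydroxypropyl gives a 1.0-fold higher number from compound 3 to compound 4 (0.01 log units; within the scatter), so moving the hydroxyl along this chain leaves the number within the scatter. The 3-hydroxypropyl group also stays within the scatter of cyclobutyl, with a 1.4-fold higher number from compound 2 to compound 4 (0.14 log units; within the scatter), while cyclopropyl remains apart, with a 3.0-fold higher number from compound 1 to compound 4 (0.48 log units; beyond the scatter), as it did for 2-hydroxypropyl. Nothing available explains why the hydroxyl can move without a shift beyond the scatter. Still open, as far as these compounds go, is whether a longer chain carrying the hydroxyl behaves the same way, and whether an amine or a carboxylic acid can stand in its place.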